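The compounds below may be only part of what the source reports. "The series", "measured", "known", "first", "only" and "open" are said of these compounds alone.

Measured so far in a functional assay on DU-145 cells (Homo sapiens) for inhibition, read by trypan blue exclusion, with a stated time of 96 h; a lower number here means a stronger inhibitor of growth, a higher number a weaker inhibitor of growth:
compound 1 `O=C(/C(=C\c1ccc[nH]1)SCc1ccc(Cl)cc1)c1ccc(Cl)cc1`: 10000 nM
compound 2 `Cc1ccc(/C=C(/SCc2ccc(Cl)cc2)C(=O)c2ccc(Cl)cc2)s1`: 50000 nM
compound 3 `Cc1cc(C)cc(/C=C(/SCc2ccc(Cl)cc2)C(=O)c2ccc(Cl)cc2)c1`: 10000 nM

Compound 3 stands level with compound 1 at the digits given, and the two share the lowest number of the three; compound 2 lies furthest from it, as a 5.0-fold lower number from compound 2 to compound 3 (0.70 log units; beyond the scatter) shows. Compound 4 `O=C(/C(=C\c1ccc(O)cc1)SCc1ccc(Cl)cc1)c1ccc(Cl)cc1` has not yet been measured. It differs from compound 3 in one place: 4-hydroxyphenyl in place of 3,5-dimethylphenyl on a double-bonded chain carbon bound to a double-bonded chain carbon. Within the data shown here, the steps that bear on this change are those in which the group at that same place was exchanged while everything else stayed fixed: a 5.0-fold higher number from compound 1 to compound 2 (0.70 log units; beyond the scatter), no change at the digits printed from compound 1 to compound 3 (within the scatter) and a 5.0-fold lower number from compound 2 to compound 3 (0.70 log units; beyond the scatter). One of these exchanges stayed within the scatter and the other two moved the number only modestly, so swapping one six-membered aromatic ring of carbon only for another is expected to give no more than a modest step in this assay, in either direction, with no change beyond the scatter the likeliest outcome. Compound 4 is therefore expected to come out near 10000 nM, between 3000 nM and 50000 nM, meaning a step of no change at the digits printed from compound 3 to compound 4 (within the scatter). Among the measured compounds shown here, the hydrogen-bond donor and acceptor that enter have no counterpart among the measured compounds, so the range is kept wide.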

Compound 4, concentration for 50% growth inhibition: 10000 nM
Compound 4: middle estimate and measured number agree at the digits printed; the range from low to high includes it.
By their numbers in this assay, from the lowest: compounds 1, 3 and 4 (each within the scatter of the next); then compound 2.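

In this assay, 4-hydroxyphenyl brings a hydrogen-bond donor and acceptor where 3,5-dimethylphenyl has neither, yet the result is no change at the digits printed from compound 3 to compound 4 (within the scatter). The same holds against the 1H-pyrrol-2-yl group, with no change at the digits printed from compound 1 to compound 4 (within the scatter), whereas the exchange for 5-methylthiophen-2-yl gives a 5.0-fold lower number from compound 2 to compound 4 (0.70 log units; beyond the scatter), so among these four compounds only compound 2 stands apart, and three differently built groups at this place cannot be told apart. No measurement at hand explains why these groups behave alike or why compound 2 differs.

From the compounds shown here alone, it remains open whether a ring carrying an amine or a carboxylic acid would also leave the number in place. Going by these compounds, it is also open whether 4-methoxyphenyl would match 4-hydroxyphenyl, which would show whether the hydroxyl hydrogen plays any part here.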